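Swapping chloro for hydrogen on compound 3: little change expected

The source may hold more compounds than are shown below. What is called first, only, known or untested is meant among the compounds shown, and "the series" means these compounds.

In a functional assay on A-375 cells (Homo sapiens) for antiproliferative activity, read by MTT assay, with a stated time of 72 h (on this read-out lower numbers stand for stronger inhibition and higher numbers for weaker inhibition), compound 3 `O=C1COc2ccc(-c3cnc(Cl)c(NS(=O)(=O)c4ccc(F)cc4)c3)cc2N1c1ccc(Cl)cc1` gives 30600 nM. Compound 2 `COc1ccc(N2C(=O)COc3ccc(-c4cnc(Cl)c(NS(=O)(=O)c5ccc(F)cc5)c4)cc32)cc1` gives 32700 nM, so the two values lie within the scatter of each other. Compound 1 `O=C1COc2ccc(-c3cnc(Cl)c(NS(=O)(=O)c4ccc(F)cc4)c3)cc2N1C1CCCCC1` gives only a limit of the assay, > 40000 nM.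

Compound 4 `O=C1COc2ccc(-c3cnc(Cl)c(NS(=O)(=O)c4ccc(F)cc4)c3)cc2N1c1ccccc1` differs from compound 3 in one place: hydrogen in place of chloro on an aromatic carbon. Hydrogen stands in place of chloro on an aromatic carbon, para to a large group, which turns 4-chlorophenyl to phenyl.

The closest measured change is chloro in place of methoxy on an aromatic carbon, which gave a 1.1-fold lower number from compound 2 to compound 3 (0.03 log units; within the scatter). Exchanging cyclohexyl for an aromatic ring gave an at least 1.2-fold lower number from compound 1 to compound 2 (0.08 log units; that floor lies within the scatter) and an at least 1.3-fold lower number from compound 1 to compound 3 (0.11 log units; that floor lies within the scatter), and these are floors rather than exact sizes. None of these steps goes beyond the scatter, so none is expected here either, and the estimated change is a 1.0-fold higher number from compound 3 to compound 4 (0.02 log units; within the scatter). For compound 4, the expected value in this assay is about 32000 nM, with an estimated range of 20000 nM to 40000 nM.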

Compound 4, half-maximal inhibitory concentration: 36900 nM
Compound 4: middle estimate off by 1.2-fold (0.06 log units), on the low side; measured number inside the range.
By their numbers in this assay, from the lowest: compounds 3, 2 and 4 (each within the scatter of the next). At a limit, above all of these: compound 1.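

Until now the ring on the amide-type nitrogen had always carried a group para to a large group, and compound 4 shows that in this assay the unsubstituted phenyl gives no measurable change from the chloro or the methoxy analogue: a 1.2-fold higher number from compound 3 to compound 4 (0.08 log units; within the scatter), and a 1.1-fold higher number from compound 2 to compound 4 (0.05 log units; within the scatter). Neither chloro nor methoxy at this place therefore shows any gain over plain hydrogen. The exchange of cyclohexyl for phenyl can be read only as a floor, an at least 1.0-fold lower number from compound 1 to compound 4 (0.03 log units; that floor lies within the scatter).

Compound 1 stands at a limit of the assay, not at an exact number: the limit of > 40000 nM in this assay, at which 1 of the 4 values shown sits.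

As far as these compounds go, whether an amine or a carboxylic acid on this phenyl ring would move the number beyond the scatter remains open. Also open, from the compounds shown here alone, is whether any change to the shared core, rather than to this ring, would do so.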